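Chloro to Nitro: The Same Change at a New Place

This account rests on a few compounds, and the source may have more. Where it says the series, first, only, none or still open, it means among the compounds named here.

Of the compounds shown here, three built on one shared core have been measured in a functional assay on U-251 cells (Homo sapiens) for inhibition, read by sulforhodamine B assay, with a stated time of 48 h; on this read-out higher numbers stand for weaker inhibition of growth and lower numbers for stronger inhibition of growth. Compound 1 `CC1=CC[C@H](C(C)(C)NC(=S)N/N=C/c2ccccc2Cl)CC1` gives 80600 nM. Compound 2 `CC1=CC[C@H](C(C)(C)NC(=S)N/N=C/c2cccc(Cl)c2)CC1` differs from compound 1 in that (3-chlorophenyl in place of 2-chlorophenyl on a carbon with a double bond to nitrogen); in this assay compound 2 gives 7900 nM, and the step is a 10-fold lower number from compound 1 to compound 2 (1.01 log units; beyond the scatter). Compound 3 `CC1=CC[C@H](C(C)(C)NC(=S)N/N=C/c2ccccc2[N+](=O)[O-])CC1` gives 20200 nM in this assay; the step of a 4.0-fold lower number from compound 1 to compound 3 (0.60 log units; beyond the scatter) goes with the change (nitro in place of chloro on an aromatic carbon). Compound 2 thus shows the lowest number of the three. Compound 4 `CC1=CC[C@H](C(C)(C)NC(=S)N/N=C/c2cccc([N+](=O)[O-])c2)CC1` has not yet been measured. It differs from compound 2 by nitro in place of chloro on an aromatic carbon. Among the measured compounds shown here, this is the same kind of change as the one from compound 1 to compound 3, but the place is not the same: there the group sits ortho to a large group, here it sits meta to a large group. For the measured compounds named here, with only the step of a 4.0-fold lower number from compound 1 to compound 3 (0.60 log units; beyond the scatter) as a guide, and the place differing, a somewhat smaller step is expected, namely a 2.5-fold lower number from compound 2 to compound 4 (0.39 log units; beyond the scatter). Compound 4 is therefore estimated at 3200 nM in this assay, with a likely range from 1200 nM to 10000 nM.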

Compound 4, concentration for 50% growth inhibition: > 100000 nM
Compound 4 gave a limit, no number (the forecaster's own chance of this, stated with the estimate: 3%); at least 31-fold (1.49 log units) between middle value and limit.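

The swap of chloro for nitro does not carry over from one core to the other in this assay, as the direction of the change reverses: the same change on two cores in this assay, a 4.0-fold lower number (0.60 log units; beyond the scatter) from compound 1 to compound 3 and an at least 12-fold higher number (1.10 log units; beyond the scatter) from compound 2 to compound 4, at least 50-fold (1.70 log units) apart, beyond the scatter of two such steps. The new step is an at least 12-fold higher number from compound 2 to compound 4 (1.10 log units; beyond the scatter), and for compound 4 the reading is a limit of the assay and not a number: the limit of > 100000 nM in this assay, at which 1 of the 4 values shown sits. These two pairs show that the step from compound 1 to compound 3 cannot serve as a guide for the same swap at the new place, but they do not show why the outcome differs, nor how large the step to compound 4 really is.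

The compounds shown leave open whether other groups on the same aromatic carbon, such as an amine, a methoxy group or a carboxylic acid, would behave more like chloro or more like nitro. They also leave open whether the reversal seen here would appear with any group other than nitro and chloro.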